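This account rests on a few compounds, and the source may have more. Where it says the series, first, only, none or still open, it means among the compounds named here.

- Compound 1 `COc1cc(-c2c(-c3ccc4cc[nH]c4c3)c(=O)c2=O)cc(OC)c1OC`: 6.6 nM
- Compound 2 `COc1cc(-c2c(-c3ccc4[nH]ccc4c3)c(=O)c2=O)cc(OC)c1OC`: 15.4 nM
- Compound 3 `COc1ccc(-c2c(-c3c(OC)cc(OC)cc3OC)c(=O)c2=O)cc1`: 850 nM
- Compound 4 `COc1ccc(-c2c(-c3cc(OC)c(OC)c(OC)c3)c(=O)c2=O)cc1Cl`: not yet measured

In a functional assay on CCRF-CEM cells (Homo sapiens) for inhibition, read by MTT assay, with a stated time of 72 h (on this read-out lower numbers stand for stronger inhibition and higher numbers for weaker inhibition), compound 2 gives 15.4 nM, the second highest of the three numbers. Compound 1 lies a little lower, and compound 3 lies far higher.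

The next change replaces the whole indole group, putting 3-chloro-4-methoxyphenyl in place of 1H-indol-5-yl on an aromatic carbon.

Going by the values given here, only one measured step changes a single place, a 2.3-fold higher number from compound 1 to compound 2 (0.37 log units; beyond the scatter), a modest step. It swaps 1H-indol-6-yl for 1H-indol-5-yl, so an indole is present on both sides, and it says little about losing that group. Compound 3 differs from compound 2 in both groups on the shared core, and compound 3 gives 850 nM, which hints that much higher numbers are possible in this series.

A modest rise therefore seems the most likely outcome, with an expected change of a 2.9-fold higher number from compound 2 to compound 4 (0.47 log units; beyond the scatter). For compound 4 the estimated value is 45 nM, with an expected range of 9 nM to 250 nM.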

Compound 4, half-maximal inhibitory concentration: 136 nM
For compound 4 the middle estimate is 3.0-fold (0.48 log units) below the measured one, within the range that was stated.
By their numbers in this assay, from the lowest: compound 1; then compound 2; then compound 4; then compound 3.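

Going by these compounds alone, compound 4 shows for the first time what happens when the indole at this position is replaced outright, with the rest of compound 2 kept, and in this assay the number rises clearly (an 8.8-fold higher number from compound 2 to compound 4 (0.95 log units; beyond the scatter)). Starting from the other indole, the same replacement gives a larger rise (a 21-fold higher number from compound 1 to compound 4 (1.31 log units; beyond the scatter)), so both indole compounds give lower numbers than the 3-chloro-4-methoxyphenyl compound, and the choice between indole and this phenyl group moves the number more than the choice between the two indoles does. No measurement shown gives a reason for these rises.

On these data alone, with only 3-chloro-4-methoxyphenyl standing in for the indole, it stays open whether the rise comes from losing the indole or from the chlorine and methoxy groups themselves. As far as these compounds go, how a phenyl ring carrying an amine or a carboxylic acid would behave at this position also stays open.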